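The source may report more compounds than this note shows. Statements on the series, on what has been measured and on what is new or still open speak of the compounds shown alone.

Compound 1 `Cc1cccc(NC(=O)c2nn(C)c3c2CCCC3)n1`: 27 nM
Compound 2 `Cc1cccc(NC(=O)c2cc(-c3ccccc3)n(C)n2)n1`: 95 nM
Compound 3 `Cc1cccc(NC(=O)c2nn(C)c(-c3ccccc3)c2C)n1`: 4.4 nM

All three were measured in a functional assay on HEK293 cells for negative allosteric modulation of metabotropic glutamate receptor 5 (Homo sapiens), read by FLIPR and calcium flux; a higher number here means a weaker inhibitor, a lower number a stronger inhibitor. Compound 3 gives the lowest number of the three; compound 1 comes nearest to it and compound 2 lies furthest away. Among the measured compounds shown here, the only measured step between two compounds that differ in a single place is a 22-fold lower number from compound 2 to compound 3 (1.33 log units; beyond the scatter). Compound 4 `Cc1cccc(NC(=O)c2nn(C)c(-c3ccc(F)cc3F)c2C)n1` differs from compound 3 by 2,4-difluorophenyl in place of phenyl on an aromatic carbon. For the measured compounds named here, no measured pair swaps one aryl group for another, so the step from compound 2 to compound 3 does not bear on this change directly. With nothing to point either way, compound 4 is expected to stay close to compound 3, a step of a 1.0-fold higher number from compound 3 to compound 4 (0.01 log units; within the scatter) within the scatter. The estimate for compound 4 is 4.5 nM, expected between 1.5 nM and 14 nM.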

Compound 4, half-maximal inhibitory concentration: 3.7 nM
Beside the measured number, compound 4's estimate is 1.2-fold (0.09 log units) above it, within the range that was stated.
By their numbers in this assay, from the lowest: compounds 4 and 3 (each within the scatter of the next); then compound 1; then compound 2.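

In this assay, 2,4-difluorophenyl in place of phenyl gives a 1.2-fold lower number from compound 3 to compound 4 (0.08 log units; within the scatter), so this aromatic carbon of the shared core tolerates the added fluorine atoms with the number staying within the scatter. Among the compounds shown here, the earlier step concerned a methyl group on the core, whereas this is the first change to the aryl group itself. No measurement shown here accounts for this result. Going by these compounds, what a methoxy group or a chlorine on that aryl ring would do, or a pyridine ring in its place, stays open.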